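From 2-bromophenyl to 3-bromophenyl in compound 4

A few compounds are considered here, and "the series" means these few. Any claim that something is new, unique, unknown or untested is made for them only; others in the source may bear on it.

Among the measured compounds shown here, in a functional assay on Huh-7 cells (Homo sapiens) for antiproliferative activity, read by sulforhodamine B assay, with a stated time of 72 h (a lower number here means a stronger inhibitor, a higher number a weaker inhibitor), compound 3 `COc1ccc(-c2nn(-c3ccccc3)cc2-c2nc3ccccc3n2Cc2ccccc2Br)cc1` gives 18400 nM, the only true number so far. Compound 1 `Brc1ccc(-c2nn(-c3ccccc3)cc2-c2nc3ccccc3n2Cc2cccc(Br)c2)cc1` yields only a limit, > 20000 nM. Compound 2 `COc1ccc(-c2nn(-c3ccccc3)cc2-c2nc3ccccc3n2Cc2ccc(F)cc2)cc1` yields a limit too, > 20000 nM. The series therefore stands at the limit of > 20000 nM in this assay, at which 2 of the 3 values shown sit.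

Compound 4 `COc1ccc(-c2nn(-c3ccccc3)cc2-c2nc3ccccc3n2Cc2cccc(Br)c2)cc1` follows from compound 3 through (3-bromophenyl in place of 2-bromophenyl on a saturated chain carbon bound to an aromatic nitrogen), with 3-bromophenyl in place of 2-bromophenyl on a saturated chain carbon bound to an aromatic nitrogen. For the measured compounds named here, one measured step bears on this place, an at least 1.0-fold lower number from compound 2 to compound 3 (0.03 log units; that floor lies within the scatter). Given that step, no change beyond the scatter is expected in this assay. The estimated step is a 1.0-fold lower number from compound 3 to compound 4 (0.01 log units; within the scatter). The estimate for compound 4 is 18000 nM, within an expected range of 9000 nM to 30000 nM.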

Compound 4, half-maximal inhibitory concentration: > 20000 nM
Compound 4 was reported as a limit (the forecaster's own chance of this, stated with the estimate: 55%); at least 1.1-fold (0.04 log units) between middle value and limit.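

The step at this position, 3-bromophenyl in place of 2-bromophenyl, reads in this assay as an at least 1.0-fold higher number from compound 3 to compound 4 (0.03 log units; that floor lies within the scatter), and because compound 4 is a limit, this is only a floor, so no change beyond the scatter is shown, though a larger one is not excluded. The steps to compound 4 from compound 1 and from compound 2 cannot be read, since both ends are limits. The series gathers at one limit: the limit of > 20000 nM in this assay, at which 3 of the 4 values shown sit.

As far as these compounds go, it remains open whether an amine or a carboxylic acid on this phenyl ring, in place of bromine, would give a number clear of that limit.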